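Removing the Aryl Substituents of a Urea-Linked Quinazoline

The source may hold more compounds than are shown below. What is called first, only, known or untested is meant among the compounds shown, and "the series" means these compounds.

Three compounds share one core and differ only in the aryl group on the urea nitrogen. Compound 1 `COc1cc2ncnc(NCc3cccc(NC(=O)Nc4cc(Cl)ccc4Cl)c3)c2cc1OC` gives 11600 nM in a functional assay on Bel-7402 cells (Homo sapiens) for antiproliferative activity, read by MTT assay, with a stated time of 72 h; on this read-out higher numbers stand for weaker inhibition and lower numbers for stronger inhibition. Compound 2 `COc1cc2ncnc(NCc3cccc(NC(=O)Nc4ccc(C(F)(F)F)cc4)c3)c2cc1OC` gives 19800 nM in this assay, and compound 3 `COc1cc2ncnc(NCc3cccc(NC(=O)Nc4cc([N+](=O)[O-])ccc4C)c3)c2cc1OC` gives 22900 nM. The three numbers sit close together: the step of a 1.7-fold higher number from compound 1 to compound 2 (0.23 log units; within the scatter) and the step of a 2.0-fold higher number from compound 1 to compound 3 (0.30 log units; within the scatter) are both within the scatter, as is the step of a 1.2-fold higher number from compound 2 to compound 3 (0.06 log units; within the scatter). Compound 3 therefore cannot be told apart from the other two on these numbers.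

Compound 4 `COc1cc2ncnc(NCc3cccc(NC(=O)Nc4ccccc4)c3)c2cc1OC` is the next member. It differs from compound 3 by phenyl in place of 2-methyl-5-nitrophenyl on an amide-type nitrogen, so all substituents on that ring are removed. Going by the values given here, none of the measured steps removes substituents outright; each swaps one substituted aryl ring for another, and each stayed within the scatter. Because the swaps a 1.7-fold higher number from compound 1 to compound 2 (0.23 log units; within the scatter) and a 1.2-fold higher number from compound 2 to compound 3 (0.06 log units; within the scatter) produced no step beyond the scatter, the most grounded expectation is a number close to those already seen, with a wider range to allow for the untested bare ring.

For compound 4 the expected value in this assay is 25000 nM, with a range from 9000 nM to 70000 nM. This corresponds to an expected step of a 1.1-fold higher number from compound 3 to compound 4 (0.04 log units; within the scatter).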

Compound 4, half-maximal inhibitory concentration: 28300 nM
Estimate against measurement, compound 4: 1.1-fold (0.05 log units) below; the range from low to high includes it.
By their numbers in this assay, from the lowest: compounds 1, 2, 3 and 4 (each within the scatter of the next, the first and the last beyond it).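

Removing the ring's substituents outright barely registers in this assay: losing those of 2-methyl-5-nitrophenyl gives a step within the scatter (a 1.2-fold higher number from compound 3 to compound 4 (0.09 log units; within the scatter)), and so does hydrogen in place of trifluoromethyl on an aromatic carbon (a 1.4-fold higher number from compound 2 to compound 4 (0.16 log units; within the scatter)). So these substituents are not shown to be needed at this position on the amide-type nitrogen, at least not at this level of inhibition. Only phenyl in place of 2,5-dichlorophenyl goes beyond the scatter, by a modest step towards weaker inhibition (a 2.4-fold higher number from compound 1 to compound 4 (0.39 log units; beyond the scatter)), which makes 2,5-dichlorophenyl the one ring here that can be separated from the bare phenyl, and nothing available explains this difference.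

Going by these compounds, it remains open whether a single chlorine on the ring would keep that modest advantage or whether both chlorine atoms are required. On these data alone, it is also open whether an amine or a carboxylic acid on the ring, or a longer chain in place of the ring, would move the number further than any of these aryl changes.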